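A few compounds are considered here, and "the series" means these few. Any claim that something is new, unique, unknown or untested is made for them only; others in the source may bear on it.

Measured compounds:
- Compound 1, `COc1ccc(C2=NO[C@]3(C2)C(=O)O[C@@H]2[C@H]3CC[C@H](C)[C@]3(O)C=CC(=O)[C@@]23C)cc1`: in a functional assay on PC-3 cells (Homo sapiens) for cytotoxicity, read by sulforhodamine B assay, with a stated time of 48 h (on this read-out lower numbers stand for stronger inhibition and higher numbers for weaker inhibition), compound 1 gives 35000 nM.
- Compound 2, `C[C@H]1CC[C@@H]2[C@@H](OC(=O)[C@]23CC(c2ccccc2Br)=NO3)[C@]2(C)C(=O)C=C[C@@]12O`: in this assay compound 2 gives 51000 nM.
- Compound 3, `C[C@H]1CC[C@@H]2[C@@H](OC(=O)[C@]23CC(c2ccc(O)cc2)=NO3)[C@]2(C)C(=O)C=C[C@@]12O`: in this assay compound 3 gives 20000 nM.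

Among these three numbers compound 1 holds the second highest. Its nearest neighbour is compound 2, with a 1.5-fold higher number from compound 1 to compound 2 (0.16 log units; within the scatter), and its furthest is compound 3, with a 1.8-fold lower number from compound 1 to compound 3 (0.24 log units; within the scatter). All three compounds share the same core and differ only in the aromatic group attached to the carbon with a double bond to nitrogen.

Compound 4, `C[C@H]1CC[C@@H]2[C@@H](OC(=O)[C@]23CC(c2ccccc2Cl)=NO3)[C@]2(C)C(=O)C=C[C@@]12O`, has not yet been measured in this assay. It differs from compound 1 in a single place: 2-chlorophenyl in place of 4-methoxyphenyl on a carbon with a double bond to nitrogen. The step that bears on it most directly is the one in which a 2-bromophenyl entered at the same place, giving a 1.5-fold higher number from compound 1 to compound 2 (0.16 log units; within the scatter). A 2-chlorophenyl closely resembles a 2-bromophenyl, so a similar outcome is expected: a step from compound 1 to compound 4 that stays within the scatter, if anything toward a slightly higher number, estimated as a 1.3-fold higher number from compound 1 to compound 4 (0.11 log units; within the scatter). Compound 4 is therefore expected to give about 45000 nM in this assay, with a range from 20000 nM to 100000 nM.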

Compound 4, half-maximal inhibitory concentration: 12000 nM
The estimate for compound 4 lay 3.8-fold (0.57 log units) above the measured number; the measured number lies below the stated range.
By their numbers in this assay, from the lowest: compounds 4, 3, 1 and 2 (each within the scatter of the next, the first and the last beyond it).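

In this assay, among the compounds shown here, the place on the carbon with a double bond to nitrogen proves more sensitive than the earlier compounds suggested: exchanging bromo for chloro on the aromatic ring gives a 4.3-fold lower number from compound 2 to compound 4 (0.63 log units; beyond the scatter), the largest step in this set. The 2-chlorophenyl also gives a 2.9-fold lower number from compound 1 to compound 4 (0.46 log units; beyond the scatter), although the 2-bromophenyl stayed within the scatter of compound 1, so two closely related groups do not behave alike here, while a 1.7-fold lower number from compound 3 to compound 4 (0.22 log units; within the scatter) leaves compound 3 and compound 4 indistinguishable. Nothing available explains why chloro and bromo differ in this way.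

On these data alone, it remains open whether a fluoro group on the aromatic ring would follow chloro or bromo, or whether a plain phenyl would match either. An amine or a carboxylic acid on that ring is also untested among these compounds.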